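Amine substituent change from compound 2 to compound 3

The compounds below may be only part of what the source reports. "The series", "measured", "known", "first", "only" and "open" are said of these compounds alone.

Measured in a functional assay on the whole organism with Mus musculus as the target, in the maximal electroshock model; a lower number here means that less compound is needed, a higher number that more compound is needed for the effect:
- compound 1 `CNC(=O)[C@@H](C)NCc1ccc(OCc2ccccc2)cc1`: 7 mg/kg
- compound 2 `CNC(=O)[C@H](CO)NCc1ccc(OCc2ccccc2)cc1`: 9.9 mg/kg

For the measured compounds named here, compound 2 stands within the scatter of compound 1, the only other measured compound, so the two numbers cannot be ranked. Compound 3 `CC[C@@H](NCc1ccc(OCc2ccccc2)cc1)C(N)=O` carries 1-carbamoylpropyl in place of 2-hydroxy-1-(methylcarbamoyl)ethyl on an amine nitrogen. Going by the values given here, one measured step bears on this change, a swap at the same place: a 1.4-fold higher number from compound 1 to compound 2 (0.15 log units; within the scatter). That step stayed within the scatter. Among the compounds with values here, no measured step covers the loss of the methyl from the methylcarbamoyl group, so this reading is only a weak guide. No step beyond the scatter is therefore expected in this assay, and no firm direction can be given. The expected step is a 1.2-fold lower number from compound 2 to compound 3 (0.07 log units; within the scatter). Compound 3 is estimated at 8.5 mg/kg, with an expected range of 4 mg/kg to 18 mg/kg.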

Compound 3, dose for half-maximal effect: 7.2 mg/kg
Compound 3: the middle estimate sits 1.2-fold (0.07 log units) above what was measured; the measured number falls inside the stated range.
By their numbers in this assay, from the lowest: compounds 1, 3 and 2 (each within the scatter of the next).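

In this assay, 1-carbamoylpropyl on the amine nitrogen gives no step beyond the scatter against 2-hydroxy-1-(methylcarbamoyl)ethyl (a 1.4-fold lower number from compound 2 to compound 3 (0.14 log units; within the scatter)) or against 1-(methylcarbamoyl)ethyl (a 1.0-fold higher number from compound 1 to compound 3 (0.01 log units; within the scatter)). The substituent can therefore lose the methyl of the methylcarbamoyl group and change its side chain in a single swap, and all three groups shown at this position still cannot be ranked. No evidence is available to explain this result.

The separate contributions of the methylcarbamoyl-to-carbamoyl change and the side-chain change remain unresolved, as the two differ together in these comparisons. Also open, as far as these compounds go, is whether a carboxylic acid in place of the carbamoyl, a longer chain such as butyl, or the opposite configuration at the stereocentre would give a step beyond the scatter.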